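Replacing a 2-chlorophenyl amide with a 2,6-difluorophenyl amide

This account rests on a few compounds, and the source may have more. Where it says the series, first, only, none or still open, it means among the compounds named here.

compound 1 `COc1cc2ncnc(Nc3ccc(NC(=O)c4cccc(C)c4)cc3)c2cc1OC`: 13000 nM
compound 2 `COc1cc2ncnc(Nc3ccc(NC(=O)c4ccc(C)cc4)cc3)c2cc1OC`: 19000 nM
compound 3 `COc1cc2ncnc(Nc3ccc(NC(=O)c4ccccc4Cl)cc3)c2cc1OC`: 36000 nM

Three amides on a shared core have been tested in a functional assay on MCF7 cells (Homo sapiens) for inhibition, read by MTT assay; a lower number here means a stronger inhibitor, a higher number a weaker inhibitor. Compound 1 gives 13000 nM, compound 2 gives 19000 nM and compound 3 gives 36000 nM. Compound 3 holds the highest number of the three: its nearest neighbour is compound 2, a 1.9-fold higher number from compound 2 to compound 3 (0.28 log units; within the scatter), and its furthest is compound 1, a 2.8-fold higher number from compound 1 to compound 3 (0.44 log units; beyond the scatter). Compound 4 `COc1cc2ncnc(Nc3ccc(NC(=O)c4c(F)cccc4F)cc3)c2cc1OC` differs from compound 3 by a single change, (2,6-difluorophenyl in place of 2-chlorophenyl on a carbonyl carbon). Within the data shown here, the measured steps that touch the amide ring, a 1.5-fold higher number from compound 1 to compound 2 (0.16 log units; within the scatter), a 2.8-fold higher number from compound 1 to compound 3 (0.44 log units; beyond the scatter) and a 1.9-fold higher number from compound 2 to compound 3 (0.28 log units; within the scatter), all stay small, and none of them involves the 2,6-difluorophenyl group itself, so there is no direct precedent for the step in this assay . On that basis compound 4 is expected to stay close to compound 3, with the estimated step of no change at the digits printed from compound 3 to compound 4 (within the scatter) lying within the scatter. Compound 4 is therefore estimated at 36000 nM, in the range 15000 nM to 90000 nM.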

Compound 4, half-maximal inhibitory concentration: 24000 nM
Beside the measured number, compound 4's estimate is 1.5-fold (0.18 log units) above it; the range from low to high includes it.
By their numbers in this assay, from the lowest: compounds 1, 2, 4 and 3 (each within the scatter of the next, the first and the last beyond it).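

In this assay, among these compounds, the 2,6-difluorophenyl group gives the first reading of this change on the carbonyl carbon, and the exchange for 2-chlorophenyl (a 1.5-fold lower number from compound 3 to compound 4 (0.18 log units; within the scatter)) does not separate the two amides. Compound 4 also stays within the scatter of both methylphenyl amides (a 1.3-fold higher number from compound 2 to compound 4 (0.10 log units; within the scatter)) (a 1.8-fold higher number from compound 1 to compound 4 (0.27 log units; within the scatter)), so it cannot be told apart from any of the three earlier compounds, even though compound 1 and compound 3 do differ from each other (a 2.8-fold higher number from compound 1 to compound 3 (0.44 log units; beyond the scatter)). Nothing measured here explains these small differences.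

The compounds shown leave open whether a ring other than a substituted phenyl, such as a pyridine, or a group such as an amine, a carboxylic acid or a longer chain would read differently on this carbonyl carbon. They also leave open whether any group here can move the number far from this range.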